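Dropping a Trifluoromethyl from a Diaryl Urea

This account rests on a few compounds, and the source may have more. Where it says the series, first, only, none or still open, it means among the compounds named here.

Three ureas sharing one core have been measured in a physicochemical assay for lipophilicity, read by HPLC, measured as octanol-water partition, at pH 7.2; on this read-out higher numbers stand for higher lipophilicity and lower numbers for lower lipophilicity. Compound 1 `NC(=O)c1ccccc1NC(=O)Nc1ccc(F)c(C(F)(F)F)c1` gives 3.3, compound 3 `CC(=O)c1ccc(NC(=O)Nc2ccc(F)c(C(F)(F)F)c2)cc1` gives 3.6, and compound 2 `O=C(Nc1ccnc(C(F)(F)F)c1)Nc1ccc(F)c(C(F)(F)F)c1` gives 3.8. Compound 2 thus sits above compound 1 by a gap beyond the scatter, while its gap to compound 3 lies within the scatter, so those two cannot be ranked.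

Compound 4 `O=C(Nc1ccncc1)Nc1ccc(F)c(C(F)(F)F)c1` differs from compound 2 in one place: hydrogen in place of trifluoromethyl on an aromatic carbon. Among the compounds with values here, since no pair of measured compounds isolates this change, the step is estimated rather than read from data. Removing a trifluoromethyl is expected to lower the distribution coefficient by a number 0.90 log units lower from compound 2 to compound 4 (beyond the scatter). Compound 4 is therefore expected to give about 2.9 in this assay, most likely between 2.5 and 3.3.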

Compound 4, distribution coefficient: 3.2
Compound 4: middle estimate off by 0.30 log units, on the low side; the measured number falls inside the stated range.
By their numbers in this assay, from the lowest: compounds 4, 1, 3 and 2 (each within the scatter of the next, the first and the last beyond it).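

The earlier compounds shown here differed from one another in more than one place, so none of them could isolate a single change. Within the data shown here, at this position on an aromatic carbon next to the ring nitrogen, putting hydrogen in place of trifluoromethyl gives a number 0.60 log units lower from compound 2 to compound 4 (beyond the scatter) in this assay and provides the first measured single-change step in this set. Nothing shown explains the size of this step.

From the compounds shown here alone, whether a methyl group, a chlorine atom or an amine at this carbon would fall closer to compound 2 or to compound 4 remains open. So does whether the same swap elsewhere on the shared core would give a similar step.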